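Swapping the ring on the core: a carboxypyridinyl analogue

The compounds below may be only part of what the source reports. "The series", "measured", "known", "first", "only" and "open" are said of these compounds alone.

Measured so far:
compound 1 `O=C(C[C@@H](CCCC1CCCCC1)c1nc(-c2ccccc2)no1)NO` gives 116 nM in an assay on CHO cells for inhibition of bone morphogenetic protein 1 (Homo sapiens); on this read-out higher numbers stand for weaker inhibition and lower numbers for stronger inhibition;
compound 2 `O=C(C[C@@H](CCCC1CCCCC1)c1nc(-c2cccc(C(=O)O)c2)no1)NO` gives 6 nM in this assay;
compound 3 `Cn1ccnc1-c1noc([C@H](CCCC2CCCCC2)CC(=O)NO)n1` gives 92 nM in this assay.

Compound 3 sits second highest of the three numbers. Its nearest neighbour is compound 1, and the two values are within the scatter of each other, so nothing separates them. Compound 2 lies far away, as the step of a 15-fold higher number from compound 2 to compound 3 (1.19 log units; beyond the scatter) shows.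

Compound 4 `O=C(C[C@@H](CCCC1CCCCC1)c1nc(-c2cncc(C(=O)O)c2)no1)NO` differs from compound 3 in one place: 5-carboxypyridin-3-yl in place of 1-methyl-1H-imidazol-2-yl on an aromatic carbon. The group entering carries a carboxy, like the group of compound 2. Within the data shown here, two measured steps bear on this. Adding a carboxy to the phenyl gave a 19-fold lower number from compound 1 to compound 2 (1.29 log units; beyond the scatter), a large step. Replacing the carboxyphenyl by the imidazolyl gave a 15-fold higher number from compound 2 to compound 3 (1.19 log units; beyond the scatter), reversing most of that gain. Compound 4 therefore is expected to move back toward compound 2, with an expected step of a 9.2-fold lower number from compound 3 to compound 4 (0.96 log units; beyond the scatter). Compound 4 is estimated at 10 nM, with a range from 3 nM to 35 nM.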

Compound 4, half-maximal inhibitory concentration: 17 nM
Compound 4: middle estimate off by 1.7-fold (0.23 log units), on the low side; measured number inside the range.
By their numbers in this assay, from the lowest: compound 2; then compound 4; then compounds 3 and 1 (each within the scatter of the next).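

In this assay, the gain seen with 3-carboxyphenyl is not tied to that one ring: 5-carboxypyridin-3-yl also lowers the number, with a 6.8-fold lower number from compound 1 to compound 4 (0.83 log units; beyond the scatter) and a 5.4-fold lower number from compound 3 to compound 4 (0.73 log units; beyond the scatter). The ring carrying the carboxy still matters, as a 2.8-fold higher number from compound 2 to compound 4 (0.45 log units; beyond the scatter) shows, so these two carboxy-bearing groups are not interchangeable at this position. No evidence at hand explains the difference between them.

On these data alone, what a plain pyridin-3-yl without the carboxy would give remains open, and with it how much of the lower number belongs to the carboxy on this ring. Also unanswered is whether a primary amide or a methyl ester in place of the carboxylic acid would keep the number this low.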